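The source may hold more compounds than are shown below. What is called first, only, known or untested is meant among the compounds shown, and "the series" means these compounds.

Compound 3 `O=C(Nc1ccc2sc(-c3ccccc3)nc2c1)N1CCCC1` carries a plain phenyl group on the shared core. In an ADME assay on HepG2 cells (Homo sapiens) for inhibition, read by resazurin assay, with a stated time of 48 h (a higher number here means that more compound is needed for the effect, a lower number that less compound is needed), compound 3 gives > 50 uM, which is a limit of the assay rather than a number. Compound 1 `O=C(Nc1ccc2sc(-c3cccc(F)c3F)nc2c1)N1CCCC1` sits at a limit as well: in this assay compound 1 gives > 50 uM. Compound 2 `O=C(Nc1ccc2sc(-c3cccc(F)c3)nc2c1)N1CCCC1` does the same, since in this assay compound 2 gives > 50 uM. All three values share (the limit of > 50 uM in this assay, at which 3 of the 3 values shown sit), so the steps a step that the two limits leave unreadable from compound 1 to compound 2, a step that the two limits leave unreadable from compound 1 to compound 3 and a step that the two limits leave unreadable from compound 2 to compound 3 cannot be sized. Compound 4 `O=C(Nc1ccc2sc(-c3ccccc3F)nc2c1)N1CCCC1` differs from compound 3 by fluoro in place of hydrogen on an aromatic carbon. Among the measured compounds shown here, no measured step offers a readable size, so the expected step that the limit leaves unreadable from compound 3 to compound 4 is taken as nothing beyond the scatter. Compound 4 is therefore expected to give about 60 uM, between 30 uM and 150 uM, most probably again as a limit.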

Compound 4, concentration for 90% of the maximal effect: > 50 uM
Compound 4 ended at the assay's limit; the forecaster's own chance of this, stated with the estimate: 85%; the middle value does not contradict the limit.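

Compound 4 stands at a limit, as do compound 1, compound 2 and compound 3, so no step from compound 4 to any of them can be read: the limit of > 50 uM in this assay, at which 4 of the 4 values shown sit.

The compounds shown leave open what actual number each would give in this assay, and whether fluoro in place of hydrogen changes it at all.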